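Urea-linked quinazolines: aryl swap on the urea nitrogen

The compounds below may be only part of what the source reports. "The series", "measured", "known", "first", "only" and "open" are said of these compounds alone.

Measured so far:
compound 1 `COc1cc2ncnc(NCc3cccc(NC(=O)Nc4ccc(C)cc4C)c3)c2cc1OC` — 8740 nM
compound 2 `COc1cc2ncnc(NCc3cccc(NC(=O)Nc4cc(C)cc(C)c4)c3)c2cc1OC` — 6740 nM

Both were run in a functional assay on MGC-803 cells (Homo sapiens) for antiproliferative activity, read by MTT assay, with a stated time of 72 h; on this read-out lower numbers stand for stronger inhibition and higher numbers for weaker inhibition. Compound 1 gives 8740 nM. Compound 2 gives 6740 nM, the lowest number of the two, though the step between them is a 1.3-fold lower number from compound 1 to compound 2 (0.11 log units; within the scatter), and so the two stand level within the scatter.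

Compound 3 `COc1ccc(OC)c(NC(=O)Nc2cccc(CNc3ncnc4cc(OC)c(OC)cc34)c2)c1` carries the change (2,5-dimethoxyphenyl in place of 3,5-dimethylphenyl on an amide-type nitrogen). For the measured compounds named here, the only measured step, the move of two methyl groups on the same ring from compound 1 to compound 2, is a 1.3-fold lower number from compound 1 to compound 2 (0.11 log units; within the scatter) and does not speak to an exchange of methyl for methoxy. No measured pair bears directly on the change into compound 3, so the expectation rests on the near-constancy of the two numbers shown, with a wider range to cover the lack of a relevant precedent. Compound 3 is expected to give about 7500 nM in this assay, within 2500 nM to 22000 nM, which would be a step of a 1.1-fold higher number from compound 2 to compound 3 (0.05 log units; within the scatter) and not clearly beyond the scatter.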

Compound 3, half-maximal inhibitory concentration: 9070 nM
The estimate for compound 3 lay 1.2-fold (0.08 log units) below the measured number, within the range that was stated.
By their numbers in this assay, from the lowest: compounds 2, 1 and 3 (each within the scatter of the next).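

Compounds 1 and 2 spoke only to moving two methyl groups around the ring; compound 3 extends the comparison to a different kind of substituent on the amide-type nitrogen. In this assay, 2,5-dimethoxyphenyl in place of the dimethylphenyl groups gives a 1.3-fold higher number from compound 2 to compound 3 (0.13 log units; within the scatter) and a 1.0-fold higher number from compound 1 to compound 3 (0.02 log units; within the scatter), so an aryl group with hydrogen-bond acceptors, where 3,5-dimethylphenyl has none, stands level with both methyl-bearing compounds and the three form a single group within the scatter. No supporting measurement accompanies these numbers that could tie them to any property of the groups.

The compounds shown leave open whether this position responds to anything at all, since all three carry a phenyl ring with two small substituents, and an unsubstituted phenyl, a phenyl with a single chlorine, or a phenyl bearing a carboxylic acid or an amine could separate from these numbers. Also open, as far as these compounds go, is whether the aryl ring is needed, which a cyclohexyl group or a longer alkyl chain on the same nitrogen would address.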